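A Methyl in Place of a Fluoro: What to Expect

The source may hold more compounds than are shown below. What is called first, only, known or untested is meant among the compounds shown, and "the series" means these compounds.

Compound 1 `Cc1ccc(C2CC(c3ccccc3)=NN2C(=O)COc2ccc(/C=C3/SC(=O)NC3=O)cc2)cc1` was tested in an assay on cells for inhibition of histone deacetylase 8 (Homo sapiens), read by fluorescence, with a stated time of 30 min (a higher number here means a weaker inhibitor, a lower number a stronger inhibitor), and gave 31000 nM. Compound 2 `O=C1NC(=O)/C(=C\c2ccc(OCC(=O)N3N=C(c4ccc(F)cc4)CC3c3ccc(F)cc3)cc2)S1` stands apart in that assay: in this assay compound 2 reaches only a limit, > 50000 nM, so no number is known for it. That point is the limit of > 50000 nM in this assay, at which 1 of the 2 values shown sits. Compound 3 `Cc1ccc(C2CC(c3ccc(F)cc3)=NN2C(=O)COc2ccc(/C=C3/SC(=O)NC3=O)cc2)cc1` is not yet measured. It differs from compound 2 by methyl in place of fluoro on an aromatic carbon, which one bond further out reads 4-fluorophenyl to 4-methylphenyl. No step between two measured compounds is available, and since compound 2 is known only as a limit, the size of this step cannot be read from the numbers shown. The step from compound 2 to compound 3 is expected to be an at least 1.2-fold lower number from compound 2 to compound 3 (0.09 log units; that floor lies within the scatter), a small move toward stronger inhibition or none beyond the scatter. For compound 3 the estimate in this assay is 40000 nM, with a range from 20000 nM to 80000 nM.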

Compound 3, half-maximal inhibitory concentration: > 50000 nM
Compound 3 ended at the assay's limit; the forecaster's own chance of this, stated with the estimate: 40%; middle value at least 1.2-fold (0.09 log units) away from the limit.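

For the compounds shown here, the result gives the first step that can be read at all in this assay: fluoro in place of hydrogen on an aromatic carbon gives an at least 1.6-fold higher number from compound 1 to compound 3 (0.20 log units; that floor lies within the scatter). That step is only a floor, so the compounds shown do not establish that adding the fluoro changes inhibition. Compound 2 and compound 3 both stand at a limit rather than at a number, and the step between them cannot be read, which leaves methyl and fluoro at this position unranked: the limit of > 50000 nM in this assay, at which 2 of the 3 values shown sit.

The compounds shown leave open how far compound 2 and compound 3 actually lie past that limit. They also leave open whether an amine or a carboxylic acid in place of the fluoro would return a measurable number in this assay.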